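Aryl swap from compound 3 to compound 4

A few compounds are considered here, and "the series" means these few. Any claim that something is new, unique, unknown or untested is made for them only; others in the source may bear on it.

Of the compounds shown here, three sharing one core have values so far in a functional assay on K562 cells (Homo sapiens) for cytotoxicity, read by MTT assay, with a stated time of 24 h (on this read-out higher numbers stand for weaker inhibition and lower numbers for stronger inhibition), on the present record. Compound 1 (`CN1C/C(=C\c2ccc(C(F)(F)F)cc2)C(=O)/C(=C/c2ccccc2F)C1`) gives 6340 nM and compound 2 (`COc1cc(/C=C2\CN(C)C/C(=C\c3ccc(Br)cc3)C2=O)cc(OC)c1OC`) gives 12400 nM on this read-out. Compound 3 (`CN1C/C(=C\c2ccc(F)cc2)C(=O)/C(=C/c2cccc([N+](=O)[O-])c2)C1`) gives 11300 nM and sits within the scatter of both compound 2 and compound 1, so its position does not set it apart from either. Among the compounds with values here, no two measured compounds differ in one place only, so the series offers no direct measure of a single change.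

Compound 4 (`CN1C/C(=C\c2cccc([N+](=O)[O-])c2)C(=O)/C(=C/c2ccc(Cl)c(Cl)c2)C1`) has no value yet. Against compound 3, it carries 3,4-dichlorophenyl in place of 4-fluorophenyl on a double-bonded chain carbon bound to a double-bonded ring carbon.

Compound 1 at 6340 nM and compound 3 at 11300 nM carry different phenyl groups yet lie within the scatter of each other, so in this assay no step beyond the scatter is expected, with only a slight lean toward stronger inhibition as a working guess. The expected step of a 1.4-fold lower number from compound 3 to compound 4 (0.15 log units; within the scatter) stays within the scatter. For compound 4 the estimate is 8000 nM with an expected range from 3000 nM to 20000 nM for this estimate.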

Compound 4, half-maximal inhibitory concentration: 15500 nM
Compound 4: the middle estimate sits 1.9-fold (0.29 log units) below what was measured; the range from low to high includes it.
By their numbers in this assay, from the lowest: compounds 1, 3, 2 and 4 (each within the scatter of the next, the first and the last beyond it).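

In this assay, within the data shown here, the first pair that differs in one place gives a direct reading: 3,4-dichlorophenyl in place of 4-fluorophenyl on a double-bonded chain carbon bound to a double-bonded ring carbon gives a 1.4-fold higher number from compound 3 to compound 4 (0.14 log units; within the scatter). The earlier compounds shown here could offer only loose comparisons across several differences, whereas this pair shows that the two groups, one with 2 chlorine and the other with 1 fluorine on the same carbon-only aromatic ring, are not separated at this position, with compound 3 at 11300 nM and compound 4 at 15500 nM. No measurement on hand offers an explanation for this result.

The compounds shown leave open whether a phenyl ring carrying an amine or a carboxylic acid at this position would give a step beyond the scatter, since the single step read here covers halogen-bearing phenyl groups only. They also leave open whether the same swap would read alike with a different aryl group held on the other side of the shared core.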